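The source may report more compounds than this note shows. Statements on the series, on what has been measured and on what is new or still open speak of the compounds shown alone.

Working notes on the series. Of the compounds shown here, two carry numbers so far. Compound 1 `CCC[C@@H](CCn1cncn1)c1ccc(Cl)cc1` gives 36.6 ug/mL in an ADME assay on HEp-2 cells (Homo sapiens) for cytotoxicity, read by MTT assay, with a stated time of 3 days; a higher number here means that more compound is tolerated, a lower number that less compound is tolerated. Compound 2 `CCCC[C@@H](CCn1cncn1)c1ccccc1` gives 40.8 ug/mL in this assay, the higher of the two numbers, though the gap to compound 1 lies within the scatter, so the two compounds read as alike. Among the compounds with values here, no step between them is tabulated, since they differ in more than one place.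

Compound 3 `CCCC[C@@H](CCn1cncn1)c1ccc(Cl)cc1` is the next compound to be measured and differs from compound 2 in a single place: chloro in place of hydrogen on an aromatic carbon. Compound 1 already carries chloro on an aromatic carbon of the same ring, and its number is close to that of compound 2. The step from compound 2 to compound 3 is therefore expected to be small, a 1.2-fold lower number from compound 2 to compound 3 (0.08 log units; within the scatter), perhaps slightly downward but not beyond the scatter. For compound 3 the estimate in this assay is 34 ug/mL, in the range 20 ug/mL to 60 ug/mL.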

Compound 3, half-maximal cytotoxic concentration: 17 ug/mL
The estimate for compound 3 lay 2.0-fold (0.30 log units) above the measured number; measured number outside the range, below it.
By their numbers in this assay, from the lowest: compound 3; then compounds 1 and 2 (each within the scatter of the next).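

In this assay chloro in place of hydrogen on an aromatic carbon, para to a large group, gives a 2.4-fold lower number from compound 2 to compound 3 (0.38 log units; beyond the scatter) on the chain of compound 2, so this position does affect the number. With chloro already in place, methyl in place of hydrogen on a saturated chain carbon, four bonds along the chain from an aromatic carbon, gives a 2.2-fold lower number from compound 1 to compound 3 (0.33 log units; beyond the scatter) and shows that the chain end also counts. Nothing measured on these compounds bears on what lies behind either step.

The compounds shown leave open whether chloro gives a step of this kind on the shorter chain, as compound 1 has no counterpart here without chloro. They also leave open how fluoro or methoxy at the same place, or a longer chain, would move the number.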